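The source may hold more compounds than are shown below. What is called first, only, known or untested is meant among the compounds shown, and "the series" means these compounds.

Compound 1 `CSc1cccc(C(=O)N2CCCC(C(=O)Nc3ccc(Cl)cc3)C2)c1` belongs to a small set of amides built on one shared core, where a substituted benzoyl group sits on one side and an anilide on the other. In an ADME assay on PC-3 cells (Homo sapiens) for cytotoxicity, read by WST assay, tested at 100 uM (a higher number here means more inhibition at the concentration tested (going by the name of the read-out), a lower number less inhibition), compound 1 gives 0%. The two companion compounds share the same core but carry a bis(trifluoromethyl)benzoyl group: compound 2 `C=CCOc1cccc(NC(=O)C2CCCN(C(=O)c3cc(C(F)(F)F)cc(C(F)(F)F)c3)C2)c1` gives 0%, and compound 3 `CC(C)(C)OC(=O)c1cccc(NC(=O)C2CCCN(C(=O)c3cc(C(F)(F)F)cc(C(F)(F)F)c3)C2)c1` gives 0%. For the measured compounds named here, the only single-point step among the measured compounds, no change at the digits printed from compound 2 to compound 3 (within the scatter), lies within the scatter, and compound 1 stands level with both compound 2 and compound 3, so no measured compound in this set shows any cytotoxic effect toward these cells at the concentration tested.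

Compound 4 `CS(=O)(=O)c1cccc(C(=O)N2CCCC(C(=O)Nc3ccc(Cl)cc3)C2)c1` differs from compound 1 at a single place: methylsulfonyl in place of methylsulfanyl on an aromatic carbon. The measured step concerns a different position and a different pair of groups, so it speaks to the present change only in a general way, by showing that swapping a substituent on the benzoyl ring moved nothing. Because compound 1 gives 0% and its companions sit at the same level, no step beyond the scatter is expected here, and no change at the digits printed from compound 1 to compound 4 (within the scatter) is expected to stay flat. Compound 4 is therefore estimated at 0%, with a likely range from -8% to 10%.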

Compound 4, a percentage reported as inhibition, at one concentration (the size of the read-out at that concentration, not a potency): 2%
The estimate for compound 4 lay 2 percentage points below the measured number; the range from low to high includes it.
By their numbers in this assay, from the lowest: compounds 1, 2, 3 and 4 (each within the scatter of the next).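

In this assay, placing methylsulfonyl instead of methylsulfanyl on this aromatic carbon gives a number 2 percentage points higher from compound 1 to compound 4 (within the scatter). For the compounds shown here, the earlier step concerned a different place and a different pair of groups, so this is the first direct reading at this position. It shows that this particular exchange, which brings in a larger group with two double bonds outside aromatic rings and adds a hydrogen-bond acceptor, does not lift the reading beyond the usual scatter, and no independent measurement is available to explain that outcome.

From the compounds shown here alone, whether an amine or a carboxylic acid on this aromatic carbon, or a longer chain in place of the methyl on sulfur, would also stay within the scatter remains open. Since all the compounds shown sit within the scatter of one another, they also leave open which change to the shared core, if any, would produce a clear reading in this assay at the concentration tested.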